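Clearance notes on the tert-butyl step from compound 3

The source may hold more compounds than are shown below. What is called first, only, known or untested is meant among the compounds shown, and "the series" means these compounds.

Measured so far in a toxicity assay on microsomes from liver (Homo sapiens) for metabolic stability, read by LC-MS, using NADPH, tested at 1 uM (on this read-out lower numbers stand for slow clearance and higher numbers for fast clearance), for this series:
- compound 1 `C[C@@H]1CN(c2scnc2-c2nc3ccccc3[nH]2)CCN1C(=O)Cn1cnc2cccnc21` gives 12 mL.min-1.g-1
- compound 2 `CCOc1ncc(-c2nc(C(F)(F)F)sc2N2CCN(C(=O)Cn3ccc4cccnc43)[C@H](C)C2)cn1` gives 316 mL.min-1.g-1
- compound 3 `Cc1nc(C)n(CC(=O)N2CCN(c3sc(C(F)(F)F)nc3-c3cnc(OC4CCC4)nc3)C[C@H]2C)n1` gives 51 mL.min-1.g-1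

Compound 3 stands second highest of the three numbers. Compound 1 lies lower and compound 2 higher, and both gaps are beyond the usual scatter.

Compound 4 `Cc1nc(C)n(CC(=O)N2CCN(c3sc(C(F)(F)F)nc3-c3cnc(C(C)(C)C)nc3)C[C@H]2C)n1` departs from compound 3 in a single place, (tert-butyl in place of cyclobutyloxy on an aromatic carbon), with tert-butyl in place of cyclobutyloxy on an aromatic carbon, between two ring nitrogen atoms.

Within the data shown here, no pair of measured compounds differs in one place only, so the series gives no direct measure of this change. The expectation therefore stays close to compound 3 at 51 mL.min-1.g-1 and carries a wide range. In this assay the expected change is a 1.1-fold lower number from compound 3 to compound 4 (0.05 log units; within the scatter), which would be no step beyond the scatter. For compound 4 the estimated value is 45 mL.min-1.g-1, with an expected range of 20 mL.min-1.g-1 to 110 mL.min-1.g-1.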

Compound 4, intrinsic clearance in microsomes: 449 mL.min-1.g-1
Estimate against measurement, compound 4: 10-fold (1.00 log units) below; measured number outside the range, above it.
By their numbers in this assay, from the lowest: compound 1; then compound 3; then compounds 2 and 4 (each within the scatter of the next).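

In this assay, tert-butyl in place of cyclobutyloxy gives an 8.8-fold higher number from compound 3 to compound 4 (0.94 log units; beyond the scatter) with the rest of the molecule unchanged. Among these compounds, this is the first one-place reading, and it shows that the read-out responds beyond the scatter to the group on this aromatic carbon, between two ring nitrogen atoms and para to a large group. Nothing in the available data gives a cause for this step.

The compounds shown leave open which difference between the two groups carries the step: the oxygen link, the four-membered ring or the branching. A cyclobutyl group or a methoxy group on the same carbon would begin to separate these differences.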